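From hydroxy to methoxy: a small change to compound 2

This account rests on a few compounds, and the source may have more. Where it says the series, first, only, none or still open, it means among the compounds named here.

Compound 1 `CC1=C2CC(C)(C)/C=C/[C@H](OC(=S)Sc3ccccc3)/C(C)=C\C3=C[C@H](C)C[C@]3(O2)C1=O`: 26000 nM
Compound 2 `C/C1=C/C2=C[C@H](C)C[C@@]23O[C@]2(CC(C)(C)[C@@H](O)[C@@H]2C1=O)[C@@H](C)C3=O`: 26000 nM

In an ADME assay on HepG2 cells (Homo sapiens) for cytotoxicity, read by CellTiter-Glo, with a stated time of 72 h (on this read-out lower numbers stand for an effect already at smaller amounts and higher numbers for an effect only at larger amounts of compound), compound 2 gives 26000 nM, level with compound 1 at 26000 nM, within the usual scatter. Compound 3 `CO[C@H]1[C@@H]2C(=O)/C(C)=C\C3=C[C@H](C)C[C@@]34O[C@]2(CC1(C)C)[C@@H](C)C4=O` differs from compound 2 in one place: methyl in place of hydrogen on an oxygen on a saturated carbon. This puts methyl in place of hydrogen on an oxygen on a saturated carbon, so hydroxy becomes methoxy. Within the data shown here, no measured pair shows this change, so the expectation is cautious. The expected step of no change at the digits printed from compound 2 to compound 3 (within the scatter) is none beyond the scatter in this assay. For compound 3 the estimated value is 26000 nM, with an expected range from 12000 nM to 55000 nM.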

Compound 3, half-maximal effective concentration: 26000 nM
Beside the measured number, compound 3's estimate shows no gap at the digits printed; the measured number falls inside the stated range.
By their numbers in this assay, from the lowest: compounds 1, 2 and 3 (each within the scatter of the next).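

The change from hydroxy to methoxy reads as no change at the digits printed from compound 2 to compound 3 (within the scatter) in this assay. For this pair, then, methyl can take the place of the hydrogen on this oxygen without moving the read-out beyond the usual scatter. Nothing available gives a reason for this outcome.

Going by these compounds, it remains open whether a longer chain on this oxygen, or an amine in place of the hydroxy, would also leave the value level. A single pair also cannot tell whether the same change elsewhere on the shared core would behave alike.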